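Compound 3: isopropylcarbonyl in place of ethylsulfonyl

The compounds below may be only part of what the source reports. "The series", "measured", "known", "first", "only" and "open" are said of these compounds alone.

Measured so far:
compound 1, `COc1cc(C)[nH]c(=O)c1CNC(=O)c1c(C)n([C@H](C)C2CCN(C(=O)OC(C)C)CC2)c2ccccc12`, gives 4.1 nM in an assay on isolated protein for inhibition of histone-lysine N-methyltransferase EZH2 variant Y641F (Homo sapiens), read by scintillation proximity assay and scintillation counting, with stated times of 30 min and 2 h; a lower number here means a stronger inhibitor, a higher number a weaker inhibitor
compound 2, `CCS(=O)(=O)N1CCC([C@@H](C)n2c(C)c(C(=O)NCc3c(OC)cc(C)[nH]c3=O)c3ccccc32)CC1`, gives 2.8 nM in this assay

Compound 2 holds the lowest of the two numbers in this assay, with compound 1 nearest to it; the step of a 1.5-fold lower number from compound 1 to compound 2 (0.17 log units; within the scatter) lies within the scatter, so the two compounds cannot be ordered on these data.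

Compound 3, `COc1cc(C)[nH]c(=O)c1CNC(=O)c1c(C)n([C@H](C)C2CCN(C(=O)C(C)C)CC2)c2ccccc12`, has not yet been measured. It differs from compound 2 in one place: isopropylcarbonyl in place of ethylsulfonyl on an amine nitrogen in a ring.

Among the compounds with values here, the only measured step that bears on this position is a 1.5-fold lower number from compound 1 to compound 2 (0.17 log units; within the scatter), in which a carbonyl-bearing group on the same ring nitrogen gave way to ethylsulfonyl with no change beyond the scatter. Compound 3 goes back from ethylsulfonyl to a carbonyl-bearing group at that nitrogen, which is the same kind of exchange in reverse. Within the data shown here, no other pair speaks to this position.

The expectation for compound 3 is therefore a step in this assay of a 1.3-fold higher number from compound 2 to compound 3 (0.10 log units; within the scatter), that is, nothing beyond the scatter in either direction. Compound 3 is estimated at 3.5 nM, within a range of 1.5 nM to 8 nM.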

Compound 3, half-maximal inhibitory concentration: 16 nM
Estimate against measurement, compound 3: 4.6-fold (0.66 log units) below, and the stated range ends below it.
By their numbers in this assay, from the lowest: compounds 2 and 1 (each within the scatter of the next); then compound 3.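

On the ring amine nitrogen of this series, the group is not interchangeable: isopropylcarbonyl in place of ethylsulfonyl produces a 5.7-fold higher number from compound 2 to compound 3 (0.76 log units; beyond the scatter) in this assay and shows that this position can move the read-out beyond the scatter. The earlier match between the isopropoxycarbonyl of compound 1 and the ethylsulfonyl of compound 2 therefore does not extend to every group with a carbonyl on this nitrogen, since isopropyl in place of isopropoxy on the carbonyl carbon gives a 3.9-fold higher number from compound 1 to compound 3 (0.59 log units; beyond the scatter) with the rest of the molecule unchanged. No measurement available here accounts for this weaker result.

Three compounds cannot show whether the isopropyl on the carbonyl carbon or the missing ether oxygen of the isopropoxy group matters more, and acetyl, cyclopropylcarbonyl, ethoxycarbonyl and methoxycarbonyl on the same nitrogen would help separate these readings. Going by these compounds, it also remains open how far the sulfonyl side extends, for example to methylsulfonyl or isopropylsulfonyl, and how a urea or the unsubstituted ring amine compares.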